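The source may report more compounds than this note shows. Statements on the series, on what has been measured and on what is new or still open speak of the compounds shown alone.

Compound 2 (`CCCN(CCC)C1CCCC1N(C(=O)CC)c1ccc(Cl)c(Cl)c1`) reads > 50 mg/kg in a functional assay on the whole organism for positive allosteric modulation, with Mus musculus as the target (a higher number here means that more compound is needed for the effect, a lower number that less compound is needed), and this is a limit of the assay, not a number. For the measured compounds named here, the only actual number so far comes from a relative with the same overall build: compound 1 (`CCC(=O)N(c1cc(Cl)cc(Cl)c1)C1CCCC1N(C)C`) reads 30 mg/kg in this assay.

Compound 3 (`CCC(=O)N(c1ccc(Cl)c(Cl)c1)C1CCCC1N(C)CCCN(C)C`) keeps everything in compound 2 except one group, with (3-(dimethylamino)propyl)(methyl)amino in place of dipropylamino on a saturated ring carbon. Going by the values given here, no measured pair shows what such a swap does, so any forecast is rough. The value of compound 1 at 30 mg/kg shows only that this family can give a real number. The expected change is an at least 1.4-fold lower number from compound 2 to compound 3 (0.15 log units; that floor lies within the scatter), a modest move towards a lower dose. Another reading at the limit would be no surprise. For compound 3 the estimated dose is 35 mg/kg, with an expected range from 15 mg/kg to 80 mg/kg.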

Compound 3, dose for half-maximal effect: 30 mg/kg
For compound 3 the middle estimate is 1.2-fold (0.07 log units) above the measured one; the measured number falls inside the stated range.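

Replacing dipropylamino with (3-(dimethylamino)propyl)(methyl)amino on this saturated ring carbon gives an actual dose: in this assay, compound 3 reads 30 mg/kg. For the compounds shown here, this is the first change in one place that can be read, and it amounts to an at least 1.6-fold lower number from compound 2 to compound 3 (0.22 log units; that floor lies within the scatter). The true size of the step remains unknown because compound 2 gives a limit of the assay, not a number: the limit of > 50 mg/kg in this assay, at which 1 of the 3 values shown sits.

The compounds shown do not reveal which part of the entering group matters, as its chain and its terminal dimethylamino arrive together. As far as these compounds go, it also remains open how this position would respond to a ring amine such as piperidine, or to a longer chain ending in the same dimethylamino.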